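The compounds below may be only part of what the source reports. "The series", "measured", "known", "first", "only" and "open" are said of these compounds alone.

Compound 1 `CC(C)=CCOc1cc(Nc2nc(C)nc(Cl)n2)ccc1Cl` and compound 2 `COc1nc(C)nc(Nc2ccc(Cl)c(OCC=C(C)C)c2)n1` share one core and differ in a single place: methoxy in place of chloro on an aromatic carbon. In an ADME assay on MT2 cells (Homo sapiens) for cytotoxicity (a lower number here means that less compound is tolerated, a higher number that more compound is tolerated), compound 1 gives 40000 nM, while compound 2 gives 12000 nM, so that this change produces a 3.3-fold lower number from compound 1 to compound 2 (0.52 log units; beyond the scatter). Compound 3 `CC(C)=CCOc1cc(Nc2ncnc(Cl)n2)ccc1C#N` carries a core whose difference from the core of compound 1 is not broken down here. In this assay compound 3 reaches only a limit, > 100000 nM. That limit is one at which a share of the values sits, (the limit of > 100000 nM in this assay, at which 1 of the 3 values shown sits). Compound 4 `COc1ncnc(Nc2ccc(C#N)c(OCC=C(C)C)c2)n1` has not yet been measured; it differs from compound 3 by methoxy in place of chloro on an aromatic carbon, the same kind of change as that between compound 1 and compound 2, although in compound 1 the place is also meta to a methyl group (1 heavy atom), which it is not in compound 3. In this assay compound 4 is expected to show a step of an at least 1.6-fold lower number from compound 3 to compound 4 (0.22 log units; that floor lies within the scatter), an expectation that rests on the earlier step of a 3.3-fold lower number from compound 1 to compound 2 (0.52 log units; beyond the scatter). Because compound 3 gives only a limit, > 100000 nM, the starting point of that step is itself uncertain. Compound 4 is therefore estimated at 60000 nM, within a range from 20000 nM to 200000 nM.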

Compound 4, half-maximal cytotoxic concentration: 42000 nM
Compound 4: the middle estimate sits 1.4-fold (0.15 log units) above what was measured; low and high end bracket the measured number.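

In this assay, methoxy in place of chloro on an aromatic carbon again moves the number the same way on a second core, giving an at least 2.3-fold lower number from compound 3 to compound 4 (0.37 log units; beyond the scatter). Compound 3 gives > 100000 nM, which is a limit of the assay and not a number, so this step has a floor but no known size. The two pairs therefore show that the direction of the change carries from the core of compound 1 to the core of compound 3, but they do not show whether its size carries over as well: the same change on two cores in this assay, a 3.3-fold lower number (0.52 log units; beyond the scatter) from compound 1 to compound 2 and an at least 2.3-fold lower number (0.37 log units; beyond the scatter) from compound 3 to compound 4; the limit leaves it open whether they differ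

The compounds shown leave open whether an amine or a longer alkoxy chain in the same place would also give a lower number than chloro. Among the compounds shown here, they also leave open whether the step from chloro to methoxy keeps its direction on cores other than these two, since only two pairs bear on it.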